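Three Limit Values and an Untested Phenol Ether

The source may report more compounds than this note shows. Statements on the series, on what has been measured and on what is new or still open speak of the compounds shown alone.

Compound 1 `Cc1ccc(S(=O)(=O)Nc2ccc3c(c2)C(=O)N(CCCCBr)C3=O)cc1`: > 200000 nM
Compound 2 `Cc1ccc(S(=O)(=O)Nc2ccc3c(c2)C(=O)N(Cc2ccccc2)C3=O)cc1`: > 200000 nM
Compound 3 `Nc1ccc2c(c1)C(=O)N(CCNc1ccccc1)C2=O`: > 200000 nM

In an assay on isolated protein for inhibition of lactase/phlorizin hydrolase (Rattus norvegicus), read by colorimetric assay (on this read-out lower numbers stand for stronger inhibition and higher numbers for weaker inhibition), compound 1 gives > 200000 nM, which is a limit of the assay and not a number. In this assay compound 2 likewise gives > 200000 nM, again a limit. Compound 3 gives > 200000 nM, also a limit. Compound 2 therefore stands nowhere on a scale of numbers: all that is known is that it sits at the limit of > 200000 nM in this assay, at which 3 of the 3 values shown sit. Among the compounds with values here, the one step between measured compounds, a step that the two limits leave unreadable from compound 1 to compound 2, cannot be read, since both of its ends are limits.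

Compound 4 `Cc1ccc(S(=O)(=O)Nc2ccc3c(c2)C(=O)N(CCOc2ccc(O)cc2)C3=O)cc1` differs from compound 2 by (4-hydroxyphenoxy)methyl in place of phenyl on a saturated chain carbon bound to an amide-type nitrogen in a ring. Within the data shown here, no measured step shows what such a change does, and every measured compound sits at the limit. The expectation for compound 4 is therefore that it too will most likely reach only the limit, giving an estimated step that the limit leaves unreadable from compound 2 to compound 4 that is not beyond the scatter. The estimated value for compound 4 is 300000 nM, expected to lie between 50000 nM and 2000000 nM.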

Compound 4, half-maximal inhibitory concentration: 100000 nM
The estimate for compound 4 lay 3.0-fold (0.48 log units) above the measured number; measured number inside the range.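

In this assay, within the data shown here, compound 4 gives 100000 nM, the first true number in this set and the first sign that a change on this chain can bring measurable inhibition. By contrast, compound 1, compound 2 and compound 3 each remain at a limit of the assay and not at a number: the limit of > 200000 nM in this assay, at which 3 of the 4 values shown sit. The change of phenyl to (4-hydroxyphenoxy)methyl gives an at least 2.0-fold lower number from compound 2 to compound 4 (0.30 log units; that floor lies within the scatter), and the change of 2-bromoethyl to 4-hydroxyphenoxy gives an at least 2.0-fold lower number from compound 1 to compound 4 (0.30 log units; that floor lies within the scatter), so both sizes are only floors.

Which part of the new group matters stays open, as the hydroxyl and the ether oxygen arrive together in this one change. Also open, from the compounds shown here alone, is what this assay would read for a carboxylic acid in place of that hydroxyl, or for a longer chain before the ether oxygen.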